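The compounds below may be only part of what the source reports. "The series", "measured", "known", "first", "only" and "open" are said of these compounds alone.

Working notes on the series in an ADME assay on HEK293 cells (Homo sapiens) for cytotoxicity, read by MTT assay, with a stated time of 48 h; a higher number here means a weaker inhibitor, a lower number a stronger inhibitor. Compound 1 `O=C1/C(=C\c2ccccc2)S/C(=N/c2ccccc2)N1Cc1ccncc1` gives 64700 nM, compound 2 `Cc1ccc(/C=C2/S/C(=N/c3ccccc3)N(Cc3ccncc3)C2=O)cc1` gives 49500 nM, and compound 3 `O=C1/C(=C\c2ccc(O)cc2)S/C(=N/c2ccccc2)N1Cc1ccncc1` gives 142000 nM, the highest number of the three. Compound 4 `COc1ccc(/C=C2/S/C(=N/c3ccccc3)N(Cc3ccncc3)C2=O)cc1` is not yet measured. It differs from compound 3 as follows: methyl in place of hydrogen on an oxygen on an aromatic ring. This is methyl in place of hydrogen on an oxygen on an aromatic ring, which turns hydroxy into methoxy.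

Going by the values given here, no measured compound carries a methoxy, so the evidence is indirect. Among the compounds with values here, three measured steps bear on the change. Hydroxy in place of hydrogen gave a 2.2-fold higher number from compound 1 to compound 3 (0.34 log units; beyond the scatter), and hydroxy in place of methyl gave a 2.9-fold higher number from compound 2 to compound 3 (0.46 log units; beyond the scatter). Methyl in place of hydrogen gave a 1.3-fold lower number from compound 1 to compound 2 (0.12 log units; within the scatter). Only compound 3 carries a hydroxy, and both steps into it are modest. Compound 4 no longer has that hydroxy, so a return toward the range of compound 1 and compound 2 is expected in this assay, though not with certainty. The expected change is a modest one toward a lower number, estimated as a 2.2-fold lower number from compound 3 to compound 4 (0.34 log units; beyond the scatter). Compound 4 is expected at about 65000 nM, with an estimated range of 32000 nM to 130000 nM.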

Compound 4, half-maximal inhibitory concentration: 47900 nM
Estimate against measurement, compound 4: 1.4-fold (0.13 log units) above, and the stated range covers the measured number.
By their numbers in this assay, from the lowest: compounds 4, 2 and 1 (each within the scatter of the next); then compound 3.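

In this assay, going by these compounds alone, methyl in place of hydrogen on the oxygen on the aromatic ring gives a 3.0-fold lower number from compound 3 to compound 4 (0.47 log units; beyond the scatter) and so removes the gap that set compound 3 apart, which the earlier compounds could suggest only indirectly. Methoxy joins the group of compounds without a hydroxy, with a 1.0-fold lower number from compound 2 to compound 4 (0.01 log units; within the scatter) and a 1.4-fold lower number from compound 1 to compound 4 (0.13 log units; within the scatter), both printed as within the scatter, so hydrogen, methyl and methoxy cannot be told apart at this place in the ring. Across the four compounds, the free hydroxy is the only change here that moves the number beyond the scatter, and the hydrogen on its oxygen is needed for that shift, since a methyl there does not keep it. No measurement at hand offers an explanation for this difference between hydroxy and methoxy.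

Going by these compounds, with a single hydroxy compound, it stays open whether the higher number belongs to hydroxy alone or would also appear with an amine or a carboxylic acid at the same place. On these data alone, it is equally open whether a longer chain on the oxygen, such as ethoxy, would behave like methoxy.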